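Series notes: benzyloxy chalcones, step from compound 3 to compound 4

The compounds below may be only part of what the source reports. "The series", "measured", "known", "first", "only" and "open" are said of these compounds alone.

The series shares one core and varies the aryl group on the double-bonded chain carbon. Compound 1, `O=C(/C=C/c1ccc(F)cc1)c1ccc(OCc2ccccc2)cc1`, is recorded in a functional assay on HCT-116 cells (Homo sapiens) for antiproliferative activity, read by sulforhodamine B assay, with a stated time of 3 days, tested at 25 uM (on this read-out lower numbers stand for a weaker effect and higher numbers for a stronger effect at the one concentration tested), as "not determined" (no result reported). Compound 2, `COc1cccc(/C=C/C(=O)c2ccc(OCc3ccccc3)cc2)c1`, gives 35.4% in this assay. Among the compounds with values here, compound 3, `COc1ccc(/C=C/C(=O)c2ccc(OCc3ccccc3)cc2)cc1`, gives 9.5% in this assay, the lowest of the two numbers available; the only measured step, a number 25.9 percentage points lower from compound 2 to compound 3 (beyond the scatter), separates it from compound 2.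

Compound 4, `O=C(/C=C/c1ccc(Cl)cc1)c1ccc(OCc2ccccc2)cc1`, differs from compound 3 by chloro in place of methoxy on an aromatic carbon. Within the data shown here, no measured step in this set exchanges methoxy for chloro; the one step available concerns only the position of methoxy, and compound 1, the nearest analogue with a halogen, has no number in this assay. There is therefore no measured basis for a directed expectation, and the step of a number 5.5 percentage points higher from compound 3 to compound 4 (within the scatter) is expected to stay within the scatter, with wide uncertainty. Compound 4 is estimated at 15% in this assay, within a range from 0% to 40%.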

Compound 4, a percentage reported as inhibition, at one concentration (the size of the read-out at that concentration, not a potency): 0.3%
For compound 4 the middle estimate is 14.7 percentage points above the measured one, within the range that was stated.
By their numbers in this assay, from the lowest: compounds 4 and 3 (each within the scatter of the next); then compound 2.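

In this assay, a number 9.2 percentage points lower from compound 3 to compound 4 (within the scatter), so on this aromatic carbon, para to a large group, chloro and methoxy are not told apart. The wider comparison gives a number 35.1 percentage points lower from compound 2 to compound 4 (beyond the scatter), which places 4-chlorophenyl with 4-methoxyphenyl in reading well apart from the 3-methoxyphenyl of compound 2, the one compound shown that goes against this low reading. No measured information accounts for these differences.

Among the compounds shown, chloro occurs only in the 4-chlorophenyl group, so it remains open whether the gap to compound 2 follows the place of the group generally or belongs to 3-methoxyphenyl alone. Also open, as far as these compounds go, is how an amine or a carboxylic acid on the same aromatic carbon would read in this assay.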